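Ester in place of tertiary-butyl amide on a thiophene-free core

The compounds below may be only part of what the source reports. "The series", "measured", "known", "first", "only" and "open" are said of these compounds alone.

Compounds measured so far in a functional assay on PC-3 cells (Homo sapiens) for inhibition, read by sulforhodamine B assay, with a stated time of 72 h; on this read-out lower numbers stand for stronger inhibition and higher numbers for weaker inhibition:
Compound 1 `Nc1sc(-c2ccc(Cl)cc2)c(-c2ccc(Cl)cc2)c1C(=O)N1CCCCC1`: 14300 nM
Compound 2 `CC1CCN(C(=O)c2c(N)sc(-c3ccc(Cl)cc3)c2-c2ccc(Cl)cc2)CC1`: 5750 nM
Compound 3 `CC(C)(C)NC(=O)c1c(N)sc(-c2ccc(Cl)cc2)c1-c1ccc(Cl)cc1`: 15100 nM

Compound 3 gives the highest of the three numbers in this assay, though one of its two gaps lies within the scatter (a 1.1-fold higher number from compound 1 to compound 3 (0.02 log units; within the scatter)), while the other is modest (a 2.6-fold higher number from compound 2 to compound 3 (0.42 log units; beyond the scatter)). Compound 4 `COC(=O)c1c(N)sc(-c2ccc(Cl)cc2)c1-c1ccc(Cl)cc1` differs from compound 3 at the carbonyl carbon: methoxy in place of (tert-butyl)amino on a carbonyl carbon. For the measured compounds named here, both steps touching that carbon stayed small, and neither replaced the amine by an alkoxy group, so no step here speaks directly to this change. Compound 4 is therefore expected to stay close to compound 3 in this assay, a step of a 1.0-fold lower number from compound 3 to compound 4 (0.00 log units; within the scatter), with an estimate of 15000 nM and a range from 5000 nM to 45000 nM.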

Compound 4, half-maximal inhibitory concentration: 2780 nM
For compound 4 the middle estimate is 5.4-fold (0.73 log units) above the measured one, and the stated range ends above it.
By their numbers in this assay, from the lowest: compound 4; then compound 2; then compounds 1 and 3 (each within the scatter of the next).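

In this assay, methoxy on the carbonyl carbon gives a lower number than each of the three amine-derived groups: (a 5.4-fold lower number from compound 3 to compound 4 (0.73 log units; beyond the scatter)), (a 5.1-fold lower number from compound 1 to compound 4 (0.71 log units; beyond the scatter)) and (a 2.1-fold lower number from compound 2 to compound 4 (0.32 log units; beyond the scatter)). Earlier, only the methyl on the saturated ring separated the amides at all, whereas this change shows that replacing the amine on this carbon by an alkoxy group also moves the number beyond the scatter. Nothing available explains this shift.

Methoxy is the only alkoxy group shown, so it remains open whether an ethoxy or isopropoxy group would behave alike. A carboxylic acid at this carbon also remains untested among these compounds.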